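The source may hold more compounds than are shown below. What is called first, only, known or untested is meant among the compounds shown, and "the series" means these compounds.

Measured so far:
- Compound 1 `C#Cc1cccc(C#Cc2ccc(CCC(=O)O)cc2)c1` gives 155 nM
- Compound 2 `Cc1cccc(C#Cc2ccc(CCC(=O)O)cc2)c1` gives 43.7 nM

Going by the values given here, in an in vitro functional assay on 1321-N1 cells for agonist activity at Free fatty acid receptor 1 (Homo sapiens), read by fluorescence (on this read-out higher numbers stand for an effect only at larger amounts of compound and lower numbers for an effect already at smaller amounts), compound 2 stands at the lower of the two numbers, and the single step that joins them, a 3.5-fold lower number from compound 1 to compound 2 (0.55 log units; beyond the scatter), lies beyond the usual scatter, so compound 2 acts at smaller amounts than compound 1.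

Compound 3 `Cc1cc(C)cc(C#Cc2ccc(CCC(=O)O)cc2)c1` differs from compound 2 by methyl in place of hydrogen on an aromatic carbon. Among the compounds with values here, the only measured step with a methyl group on this ring is the one from compound 1 to compound 2, and there a methyl replaced an ethynyl group; no measured pair shows what a second methyl on the same ring does. That step was modest in size, and the present change is smaller in kind, adding a group where only a hydrogen stood. The expected outcome in this assay is therefore a step no larger than the scatter, with no clear direction. For compound 3 the estimate is 35 nM, with a range from 12 nM to 110 nM, which means an expected step of a 1.2-fold lower number from compound 2 to compound 3 (0.10 log units; within the scatter).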

Compound 3, half-maximal effective concentration: 74.1 nM
Estimate against measurement, compound 3: 2.1-fold (0.33 log units) below; measured number inside the range.
By their numbers in this assay, from the lowest: compounds 2 and 3 (each within the scatter of the next); then compound 1.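

In this assay, a methyl in place of hydrogen on an aromatic carbon, meta to a large group and meta to a methyl group, gives a step that lies within the usual scatter (a 1.7-fold higher number from compound 2 to compound 3 (0.23 log units; within the scatter)), so compound 2 and compound 3 cannot be told apart. The earlier pair showed only methyl in place of ethynyl on this ring, whereas this pair shows a second methyl on the same ring, with one more carbon atom on the molecule and no difference that these measurements can separate from ordinary variation. No measured property of these compounds bears on this result, so it offers no explanation for it.

As far as these compounds go, it remains open whether a larger or different group on this aromatic carbon, such as ethyl, methoxy or an amine, would produce a step beyond the scatter. Also open, from the compounds shown here alone, is whether a methyl on this carbon would have the same small effect if the other ring substituent were ethynyl, as it is in compound 1.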